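Removing one methoxy group from a weakly cytotoxic chalcone series

The source may hold more compounds than are shown below. What is called first, only, known or untested is meant among the compounds shown, and "the series" means these compounds.

Compound 1 `COc1cc(-c2cc(/C=C/C(=O)c3ccc(N)cc3)[nH]n2)cc(OC)c1OC`: 98%
Compound 2 `COc1ccc(C(=O)/C=C/c2cc(-c3cc(OC)c(OC)c(OC)c3)n[nH]2)cc1OC`: 90%
Compound 3 `COc1ccc(C(=O)/C=C/c2cc(-c3cc(OC)c(OC)c(OC)c3)n[nH]2)cc1`: 90%

All three were tested in a functional assay on NCI/ADR-RES cells (Homo sapiens) for cytotoxicity, read by sulforhodamine B assay, with a stated time of 48 h, tested at 1 uM; a lower number here means a stronger effect, a higher number a weaker effect of the compound at the concentration tested. In this assay compound 1 gives 98%, compound 2 gives 90% and compound 3 gives 90%; at this concentration none of them holds the cells back much. Compounds 2 and 3 differ by one change, (hydrogen in place of methoxy on an aromatic carbon), and that change made a step of no change at the digits printed from compound 2 to compound 3 (within the scatter).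

Compound 4 `COc1ccc(-c2cc(/C=C/C(=O)c3ccc(N)cc3)[nH]n2)cc1OC` has not yet been measured. It stands to compound 1 as compound 3 stands to compound 2: the difference is hydrogen in place of methoxy on an aromatic carbon. The surroundings are not quite the same, since in compound 1 the carbon that loses the methoxy group is also "meta to a methoxy group (2 heavy atoms)", so this is the same kind of change rather than the same change. The two cores differ as well, by 4-aminophenyl in place of 3,4-dimethoxyphenyl on a carbonyl carbon; the steps of a number 8 percentage points lower from compound 1 to compound 2 (within the scatter) and a number 8 percentage points lower from compound 1 to compound 3 (within the scatter) show that this core difference does little here.

Given the earlier step of no change at the digits printed from compound 2 to compound 3 (within the scatter) and the value that compound 1 gives, 98%, compound 4 is expected to show a step of about a number 2 percentage points lower from compound 1 to compound 4 (within the scatter). The estimate for compound 4 is 96%, expected to fall between 86% and 104%.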

Compound 4, a percentage reported as activity, at one concentration (the size of the read-out at that concentration, not a potency): 99%
For compound 4 the middle estimate is 3 percentage points below the measured one, and the stated range covers the measured number.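

In this assay, replacing one methoxy group with hydrogen on the core of compound 1 gave a step of a number 1 percentage points higher from compound 1 to compound 4 (within the scatter), so the change leaves the number where it was on this core. Set beside the earlier case, the change carries over from one core to the other without any visible difference: the same change on two cores in this assay, no change at the digits printed (within the scatter) from compound 2 to compound 3 and a number 1 percentage points higher (within the scatter) from compound 1 to compound 4, 1 percentage points apart, within the scatter of two such steps. Going by these compounds alone, this shows only that the change does nothing detectable on either core under these conditions; all four compounds hold the cells back little at the single concentration tested, so two flat steps cannot tell whether the change would also be silent on a compound with a clear effect, or whether the two cores would still agree there.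

The compounds shown leave open whether a different replacement at this place on the ring, such as a hydroxyl group, an amine or a longer ether chain like ethoxy, would move the number at all. They also leave open what happens when the remaining methoxy groups are replaced, and whether the amino group of compound 4 matters once a compound in this series has a real effect on these cells.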